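Carbamate variation on a shared core: from tert-butyl to pentyl

The source may hold more compounds than are shown below. What is called first, only, known or untested is meant among the compounds shown, and "the series" means these compounds.

Compound 1 `CCOC(=O)N1CCN(C(=O)c2nc(Nc3cc(C4CC4)[nH]n3)c3cc(Cl)ccc3n2)C[C@H]1C`: 79.2%
Compound 2 `C[C@@H]1CN(C(=O)c2nc(Nc3cc(C4CC4)[nH]n3)c3cc(Cl)ccc3n2)CCN1C(=O)OC(C)(C)C`: 22.7%

Going by the values given here, in an assay for inhibition of serine/threonine-protein kinase PAK 4 (Homo sapiens), read by FRET and Z'-LYTE, with a stated time of 60 min, tested at 5 uM, in the presence of a further agent that is not named here (on this read-out lower numbers stand for a weaker effect and higher numbers for a stronger effect at the one concentration tested), compound 2 stands lowest of the two numbers, with compound 1 the nearest and higher, the step of a number 56.5 percentage points lower from compound 1 to compound 2 (beyond the scatter) being the only measured step. Compound 3 `CCCCCOC(=O)N1CCN(C(=O)c2nc(Nc3cc(C4CC4)[nH]n3)c3cc(Cl)ccc3n2)C[C@H]1C` differs from compound 2 by pentyl in place of tert-butyl on an oxygen next to a carbonyl group. Among the compounds with values here, the one measured step concerns a branched group replacing a straight chain at the same place, so a return to a straight chain is expected to raise the number, though how far is uncertain, estimated as a number 32.3 percentage points higher from compound 2 to compound 3 (beyond the scatter). Compound 3 is therefore expected to give about 55%, within 25% to 85%.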

Compound 3, a percentage reported as inhibition, at one concentration (the size of the read-out at that concentration, not a potency): 12.6%
Compound 3: middle estimate off by 42.4 percentage points, on the high side; the measured number lies below the stated range.
By their numbers in this assay, from the lowest: compound 3; then compound 2; then compound 1.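

In this assay, a straight chain does not bring the number back: pentyl in place of tert-butyl gives a number 10.1 percentage points lower from compound 2 to compound 3 (beyond the scatter), and lengthening the ethyl group to pentyl gives a number 66.6 percentage points lower from compound 1 to compound 3 (beyond the scatter). At this position, then, straight chains as well as branched groups can lie far below ethyl, so branching alone does not separate the high number from the low numbers among these three compounds. Nothing available explains this drop.

As far as these compounds go, it remains open how methyl or propyl on this oxygen would read, and whether any such group would match or exceed ethyl. From the compounds shown here alone, a chain ending in an amine is equally open.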